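The source may hold more compounds than are shown below. What is called first, only, known or untested is meant among the compounds shown, and "the series" means these compounds.

Notes on the series, read in a functional assay on HCT-116 cells (Homo sapiens) for inhibition, read by colorimetric assay, with a stated time of 3 days; a lower number here means a stronger inhibitor, a higher number a weaker inhibitor. Compound 1 `O=C(CCCCCCNC(=O)C(O)(O)C(F)(F)F)Nc1ccc(S(F)(F)(F)(F)F)cc1` gives 9110 nM. Compound 2 `O=C(CCCCCCNC(=O)C(O)(O)C(F)(F)F)Nc1ccc(C(=O)c2ccccc2)cc1` carries benzoyl on the same aromatic carbon.

Compound 2 returns only a limit, > 40000 nM, and not a number. On these data alone, it therefore stands at the limit of > 40000 nM in this assay, at which 1 of the 2 values shown sits, and its true distance from compound 1 remains open. Going by the values given here, the one measured step at this aromatic carbon is an at least 4.3-fold higher number from compound 1 to compound 2 (0.64 log units; beyond the scatter).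

Compound 3 `O=C(CCCCCCNC(=O)C(O)(O)C(F)(F)F)Nc1ccc(-c2ccccc2)cc1` has phenyl in place of benzoyl on an aromatic carbon, para to a large group: phenyl in place of benzoyl on an aromatic carbon. Among the compounds with values here, no measured step covers this exact change. Within the data shown here, the only guide is the step of an at least 4.3-fold higher number from compound 1 to compound 2 (0.64 log units; beyond the scatter), which shows that a swap at this carbon can move the number in this assay by a modest amount or more. A modest step towards a lower number is therefore expected in this assay, though compound 3 may also end at the limit.

The estimated value for compound 3 is 16000 nM, with an expected range of 5000 nM to 40000 nM. The estimate implies an at least 2.5-fold lower number from compound 2 to compound 3 (0.39 log units; beyond the scatter).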

Compound 3, half-maximal inhibitory concentration: 4730 nM
Compound 3: the middle estimate sits 3.4-fold (0.53 log units) above what was measured, outside the stated range (below it).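

Phenyl in place of benzoyl on this aromatic carbon, para to a large group, gives an at least 8.4-fold lower number from compound 2 to compound 3 (0.92 log units; beyond the scatter), so this single swap is enough to bring the reading in this assay from a limit to a measured number. The two groups without a carbonyl, phenyl and pentafluorosulfanyl, cannot be separated, although one is a six-membered aromatic ring and the other has no ring: a 1.9-fold lower number from compound 1 to compound 3 (0.28 log units; within the scatter). Compound 2 is the only one of the three compounds at a limit, so the measured steps to it give a minimum and not a true size: the limit of > 40000 nM in this assay, at which 1 of the 3 values shown sits.

The compounds shown do not tell whether the carbonyl alone or the benzoyl group as a whole accounts for the gap, as benzoyl is the only carbonyl-bearing group shown at this carbon. On these data alone, how an amine or a carboxylic acid on this aromatic carbon would read in this assay, and whether a longer chain in the shared core would shift these readings, also stays open.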